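The compounds below may be only part of what the source reports. "The series", "measured", "known", "first", "only" and "open" are said of these compounds alone.

Measured so far in a functional assay on MGC-803 cells (Homo sapiens) for antiproliferative activity, read by MTT assay, with a stated time of 72 h; a lower number here means a stronger inhibitor, a higher number a weaker inhibitor:

Compound 1 `O=C(N/N=C/c1ccco1)c1cccc(S(=O)(=O)N2CCOCC2)c1`: > 100000 nM (a limit of the assay)
Compound 2 `O=C(N/N=C/c1ccccn1)c1cccc(S(=O)(=O)N2CCOCC2)c1`: 81700 nM
Compound 3 `O=C(N/N=C/c1ccccc1O)c1cccc(S(=O)(=O)N2CCOCC2)c1`: 25300 nM

The value of compound 1 is not a number but (the limit of > 100000 nM in this assay, at which 1 of the 3 values shown sits). Against that limit, the exchange of rings gave an at least 1.2-fold lower number from compound 1 to compound 2 (0.08 log units; that floor lies within the scatter) and an at least 3.9-fold lower number from compound 1 to compound 3 (0.59 log units; beyond the scatter). Between the two real numbers, the exchange gave a 3.2-fold lower number from compound 2 to compound 3 (0.51 log units; beyond the scatter). Compound 3 therefore holds the lowest of the two numbers, with compound 2 as its nearest neighbour.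

Compound 4 `CCN(CC)c1ccc(/C=N/NC(=O)c2cccc(S(=O)(=O)N3CCOCC3)c2)c(O)c1` keeps the whole of compound 3 and differs in one place: diethylamino in place of hydrogen on an aromatic carbon. For the measured compounds named here, none of the measured steps is of this kind; each of them swapped the entire ring on the carbon with the double bond to nitrogen, and the largest of them was only modest. Going by the values given here, no step adds a group to a ring that is otherwise unchanged, so the measured steps give no direct guide, only the sense that single changes at this end of the molecule have shifted the number by modest amounts. Compound 4 is expected to give 10000 nM in this assay, within 2500 nM to 40000 nM. That estimate means a step of a 2.5-fold lower number from compound 3 to compound 4 (0.40 log units; beyond the scatter).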

Compound 4, half-maximal inhibitory concentration: 4040 nM
Beside the measured number, compound 4's estimate is 2.5-fold (0.39 log units) above it; measured number inside the range.
By their numbers in this assay, from the lowest: compound 4; then compound 3; then compound 2. At a limit, above all of these: compound 1.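

In this assay, every earlier step replaced one whole ring with another, whereas this change keeps the 2-hydroxyphenyl ring and adds diethylamino on an aromatic carbon, para to a large group and meta to the hydroxy group. That single addition gives a 6.3-fold lower number from compound 3 to compound 4 (0.80 log units; beyond the scatter) with the ring itself left in place, so the number at this end of the molecule can be moved by adding to a ring as well as by exchanging it. For the compounds shown here, this carbon, which carries only hydrogen in the earlier compounds, therefore accepts a group of 5 heavy atoms, and the number still falls rather than rises.

Still open, as far as these compounds go, is whether this fall belongs to diethylamino in particular or would also come with another group on the same carbon, such as dimethylamino, methoxy or a carboxylic acid, and whether diethylamino would act alike on the pyridin-2-yl ring. Nothing in the data shown accounts for the size of this step.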